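The source may hold more compounds than are shown below. What is called first, only, known or untested is meant among the compounds shown, and "the series" means these compounds.

Measured so far in a functional assay on MV4-11 cells (Homo sapiens) for inhibition, with a stated time of 120 h, tested at 10 uM; a lower number here means less inhibition, a higher number more inhibition at the concentration tested (going by the name of the read-out): compound 1 `Cc1n[nH]c2ccc(-c3nc4cnc(N5CCN(C)CC5)cn4c3Nc3cccc(Cl)c3)cc12` gives 0%; compound 2 `Cc1cc(Br)ccc1Nc1c(-c2ccc3[nH]nc(C)c3c2)nc2cnc(N3CCN(C)CC3)cn12` gives 59.4%.

Compound 1 is the lowest of the two numbers in this assay; its nearest neighbour is compound 2, reached by a number 59.4 percentage points higher from compound 1 to compound 2 (beyond the scatter). Going by the values given here, that single measured step swapped the ring on the nitrogen on the aromatic ring, 4-bromo-2-methylphenyl in place of 3-chlorophenyl, and it is the only information on what this ring does.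

Compound 3 `Cc1n[nH]c2ccc(-c3nc4cnc(N5CCN(C)CC5)cn4c3Nc3ccc(Cl)cc3Cl)cc12` is not yet measured. It differs from compound 1 by 2,4-dichlorophenyl in place of 3-chlorophenyl on a nitrogen on an aromatic ring. The step to compound 2 bears on this only in part: it shows that leaving 3-chlorophenyl for another substituted phenyl on the same nitrogen can raise inhibition by a large amount, but the ring entering here, 2,4-dichlorophenyl, is not the one tested there, so the size is uncertain.

Given the size of a number 59.4 percentage points higher from compound 1 to compound 2 (beyond the scatter), a rise beyond the scatter is expected for compound 3, though smaller and with wide uncertainty; the estimated step is a number 35 percentage points higher from compound 1 to compound 3 (beyond the scatter). Compound 3 is therefore estimated at 35%, within 0% to 75%.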

Compound 3, a percentage reported as inhibition, at one concentration (the size of the read-out at that concentration, not a potency): 78.8%
Compound 3: middle estimate off by 43.8 percentage points, on the low side; measured number above the stated range.
By their numbers in this assay, from the lowest: compound 1; then compound 2; then compound 3.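

In this assay, the nitrogen on an aromatic ring now has a second replacement for 3-chlorophenyl that raises inhibition: 2,4-dichlorophenyl gives a number 78.8 percentage points higher from compound 1 to compound 3 (beyond the scatter), so the gain is not specific to the 4-bromo-2-methylphenyl ring of compound 2. The two replacements also differ from each other, with a number 19.4 percentage points higher from compound 2 to compound 3 (beyond the scatter), so this position separates 2,4-dichlorophenyl from 4-bromo-2-methylphenyl as well as both from 3-chlorophenyl. Within these three compounds, the two rings whose names carry groups at 2 and 4 stand higher than the 3-chlorophenyl ring of compound 1, although no data here give a cause for either step.

Still open, going by these compounds, is which part of the change matters, since 2,4-dichlorophenyl differs from 3-chlorophenyl in both the number and the placement of its chlorines, and 2-chlorophenyl, 4-chlorophenyl and unsubstituted phenyl would be needed to separate those two changes. Going by these compounds alone, also open is whether halogens are needed at all, which a methoxy group on the phenyl ring or a pyridine ring in its place would test, and these single-concentration readings give no potency for any compound.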